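Sulfonyl Substituent Change Where Both Neighbours Sit at the Limit

The compounds below may be only part of what the source reports. "The series", "measured", "known", "first", "only" and "open" are said of these compounds alone.

Compound 1, `CC[C@H](C)[C@H](NC(=O)c1cccc(Cn2ccnc2)c1)C(=O)NNS(=O)(=O)c1ccccc1`: > 100000 nM
Compound 2, `CCCCS(=O)(=O)NNC(=O)[C@@H](NC(=O)c1cccc(Cn2ccnc2)c1)[C@@H](C)CC`: > 100000 nM

In an assay on HEK293 cells for displacement of a labelled ligand from Type-2 angiotensin II receptor (Homo sapiens) (on this read-out lower numbers stand for stronger inhibition and higher numbers for weaker inhibition), compound 1 gives only a limit, > 100000 nM; that number is the edge of what the assay can report, not a measured strength. In this assay compound 2 likewise gives only a limit, > 100000 nM. Compound 2 therefore stands at the floor of the shown numbers, with nothing to separate it from compound 1. Going by the values given here, the one measured step, a step that the two limits leave unreadable from compound 1 to compound 2, cannot be sized because of the limit of > 100000 nM in this assay, at which 2 of the 2 values shown sit.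

Compound 3, `CC[C@H](C)[C@H](NC(=O)c1cccc(Cn2ccnc2)c1)C(=O)NNS(=O)(=O)c1c(C)cc(C)cc1C`, differs from compound 2 by 2,4,6-trimethylphenyl in place of butyl on a sulfonyl sulfur. The measured step bears on the same sulfonyl position but is itself unreadable, so no direction can be taken from it. With both neighbours at the limit, compound 3 is expected to remain there as well. Compound 3 is estimated at 100000 nM, within 30000 nM to 300000 nM. The step of a number no higher from compound 2 to compound 3 (the limit leaves the size open) is the expected consequence.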

Compound 3, inhibition constant: 8500 nM
The estimate for compound 3 lay 12-fold (1.07 log units) above the measured number; the measured number lies below the stated range.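

Putting 2,4,6-trimethylphenyl in place of butyl on the sulfonyl sulfur gives an at least 11-fold lower number from compound 2 to compound 3 (1.07 log units; beyond the scatter) in this assay, the first sign that this position can move the read-out at all. Putting the same group in place of phenyl gives an at least 11-fold lower number from compound 1 to compound 3 (1.07 log units; beyond the scatter), so the change still counts when the sulfur already carries an aromatic ring. An unsubstituted ring is therefore not enough in this series: compound 1 gives only a limit, > 100000 nM.

Going by these compounds, the step between butyl and phenyl cannot be read, because both values sit at the edge of the assay: the limit of > 100000 nM in this assay, at which 2 of the 3 values shown sit. It also remains open whether the full 2,4,6-trimethylphenyl group is needed, or whether a phenyl carrying a single methyl, a naphthyl or a longer chain on the sulfur would give a measurable number.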